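The compounds below may be only part of what the source reports. "The series", "measured", "known", "first", "only" and "open" are said of these compounds alone.

Working notes on the series, read in a functional assay on MCF7 cells (Homo sapiens) for cytotoxicity, read by MTT assay, with a stated time of 72 h; a lower number here means a stronger inhibitor, a higher number a weaker inhibitor. For the measured compounds named here, compound 1 (`CN(C)CCCCCn1c2c(c3ccccc31)C(=O)c1c[n+]([O-])c3ccccc3c1C2=O`) gives 200 nM, the lower of the two numbers so far. Compound 2 (`O=C1c2c[n+]([O-])c3ccccc3c2C(=O)c2c1c1ccccc1n2Cc1cn([C@H]2O[C@H](CO)[C@@H](O)[C@H]2O)nn1`) gives 1490 nM, a higher number by a margin beyond the usual scatter. Compound 3 (`O=C1c2c[n+]([O-])c3ccccc3c2C(=O)c2c1c1ccccc1n2CCCCn1ccnc1`) has not yet been measured. Its difference from compound 1 is 1H-imidazol-1-yl in place of (dimethylamino)methyl on a saturated chain carbon, four bonds along the chain from an aromatic nitrogen. Going by the values given here, no measured pair shows this change, so the expectation is loose. A moderate rise in the number is expected, of a size near the edge of the scatter. The expected step runs a 2.0-fold higher number from compound 1 to compound 3 (0.30 log units; within the scatter). The estimate for compound 3 is 400 nM, with an expected range of 130 nM to 1200 nM.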

Compound 3, half-maximal inhibitory concentration: 130 nM
The estimate for compound 3 lay 3.1-fold (0.49 log units) above the measured number, and the stated range covers the measured number.
By their numbers in this assay, from the lowest: compounds 3 and 1 (each within the scatter of the next); then compound 2.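

In this assay, 1H-imidazol-1-yl in place of (dimethylamino)methyl on a saturated chain carbon, four bonds along the chain from an aromatic nitrogen, gives a 1.5-fold lower number from compound 1 to compound 3 (0.19 log units; within the scatter), so this pair does not separate the two groups. At this position, then, a five-membered aromatic ring can stand in for the open-chain dimethylamino group with no change beyond the scatter, although this rests on a single pair. Nothing at hand bears on the reason for this result.

Still open, as far as these compounds go, is whether a morpholine, a piperidine or a carboxylic acid in the place of 1H-imidazol-1-yl would leave the number within the scatter as well. Also open, from the compounds shown here alone, is how a shorter or longer chain carrying 1H-imidazol-1-yl would read in this assay.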